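Compound 4: chloro in place of hydrogen on compound 1

This account rests on a few compounds, and the source may have more. Where it says the series, first, only, none or still open, it means among the compounds named here.

Compound 1 `COc1ccc(NC(=O)Nc2cc(C)nc3ccccc23)cc1` has two measured relatives, compound 2 `Cc1cc(NC(=O)Nc2ccc(N)cc2)c2ccccc2n1` and compound 3 `Cc1cc(NC(=O)Nc2ccc(O)cc2)c2ccccc2n1`. In an ADME assay on HEK293 cells (Homo sapiens) for cytotoxicity, with a stated time of 72 h (a lower number here means that less compound is needed, a higher number that more compound is needed for the effect), compound 1 gives > 25000 nM, which is a limit of the assay and not a number. Compound 2 gives > 25000 nM, also a limit. Compound 3 gives > 25000 nM, likewise a limit. Because (the limit of > 25000 nM in this assay, at which 3 of the 3 values shown sit), the steps a step that the two limits leave unreadable from compound 1 to compound 2, a step that the two limits leave unreadable from compound 1 to compound 3 and a step that the two limits leave unreadable from compound 2 to compound 3 carry no readable size. Compound 4 `COc1ccc(NC(=O)Nc2cc(C)nc3ccccc23)cc1Cl` differs from compound 1 by chloro in place of hydrogen on an aromatic carbon. Going by the values given here, none of the measured steps covers this change, and none has a readable size, so no step beyond the scatter is expected in this assay in either direction. For compound 4 the value is estimated at 30000 nM, within 10000 nM to 80000 nM, with the step that the limit leaves unreadable from compound 1 to compound 4 expected to be small.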

Compound 4, half-maximal effective concentration: 26000 nM
The estimate for compound 4 lay 1.2-fold (0.06 log units) above the measured number; low and high end bracket the measured number.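

No step from compound 1 to compound 4 can be read in this assay, because compound 1 carries a limit and not a number: the limit of > 25000 nM in this assay, at which 3 of the 4 values shown sit.

From the compounds shown here alone, what chloro in place of hydrogen on an aromatic carbon does to the value of compound 1 stays open, as does any order among compound 1, compound 2 and compound 3.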